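This account rests on a few compounds, and the source may have more. Where it says the series, first, only, none or still open, it means among the compounds named here.

In an ADME assay on microsomes from liver (Mus musculus) for metabolic stability, read by LC-MS, with a stated time of 10 min (on this read-out higher numbers stand for a more stable compound and lower numbers for a less stable compound), compound 3 `C[C@@H]1CN(c2cccc3c2C[C@H](CN(C)[C@H]2CCCc4cccnc42)NC3)C[C@H](C)N1C` gives 39.6%. That number lies within the scatter of compound 1 `CN(C[C@H]1Cc2c(cccc2N2CCN3CCC[C@@H]3C2)CN1)[C@H]1CCCc2cccnc21` at 36.7%, and well short of compound 2 `CN(C[C@H]1Cc2c(cccc2N2CCN(c3cccc(C(F)(F)F)c3)CC2)CN1)[C@H]1CCCc2cccnc21` at 72.3%. Compound 4 `CCN1CCN(c2cccc3c2C[C@H](CN(C)[C@H]2CCCc4cccnc42)NC3)CC1` keeps the shared core and alters one group: 4-ethylpiperazin-1-yl in place of 3,4,5-trimethylpiperazin-1-yl on an aromatic carbon. Among the measured compounds shown here, the one measured step that bears on this is another exchange on that aromatic carbon, a number 2.9 percentage points higher from compound 1 to compound 3 (within the scatter). Compound 2 offers less guidance, as only its group carries a trifluoromethyl. From the step to compound 3, no step beyond the scatter is expected in this assay. The expected step is a number 1.6 percentage points lower from compound 3 to compound 4 (within the scatter). Compound 4 is expected at 38%, with an estimated range from 24% to 54%.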

Compound 4, percent of the compound remaining: 18.8%
For compound 4 the middle estimate is 19.2 percentage points above the measured one; the measured number lies below the stated range.
By their numbers in this assay, from the lowest: compound 4; then compounds 1 and 3 (each within the scatter of the next); then compound 2.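

In this assay, the aromatic carbon proves sensitive to the group it carries: 4-ethylpiperazin-1-yl in place of 3,4,5-trimethylpiperazin-1-yl gives a number 20.8 percentage points lower from compound 3 to compound 4 (beyond the scatter), and the exchange from the fused bicyclic group gives a number 17.9 percentage points lower from compound 1 to compound 4 (beyond the scatter). Compound 4 thus separates from both compound 1 and compound 3, unlike the earlier step between those two, which stayed within the scatter. On the amine nitrogen in the ring, ethyl in place of 3-(trifluoromethyl)phenyl gives a number 53.5 percentage points lower from compound 2 to compound 4 (beyond the scatter), the largest step here. Nothing measured here explains these falls. As far as these compounds go, whether a propyl chain or an unsubstituted phenyl on that nitrogen would sit nearer compound 4 or compound 2 remains open.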